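The source may hold more compounds than are shown below. What is called first, only, known or untested is meant among the compounds shown, and "the series" means these compounds.

Measured in an ADME assay on microsomes from liver (Homo sapiens) for metabolic stability, read by LC-MS, using NADPH, with a stated time of 10 min, tested at 0.5 uM; on this read-out lower numbers stand for a less stable compound and higher numbers for a more stable compound:

compound 1 `COC(=O)Nc1cc(-c2cnc(OC[C@@](C)(N)CC(C)C)c(OC)c2)ccn1`: 86%
compound 2 `CC(=O)Nc1cc(-c2cc(F)c(OC[C@@H](N)CC(C)C)cc2F)ccn1`: 78%
compound 3 `CC(=O)Nc1cc(-c2ccc(OC[C@@H](N)CC(C)C)c(Cl)c2)ccn1`: 89%

Compound 1 gives the second highest of the three numbers in this assay. Its nearest neighbour is compound 3, a few points higher, and compound 2 lies somewhat lower; both gaps fall within the scatter, so the three cannot be ordered.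

Compound 4 `COC(=O)Nc1cc(-c2cnc(OC[C@@](C)(N)CC(C)C)c(C#N)c2)ccn1` differs from compound 1 in one place: cyano in place of methoxy on an aromatic carbon. The change sits ortho to the (2-amino-2,4-dimethylpentyl)oxy group and two atoms from the ring nitrogen. Within the data shown here, no measured pair shows the effect of this exchange. Given the narrow band of the three values, no step beyond the scatter is expected in this assay. The step from compound 1 to compound 4 is estimated at a number 2 percentage points lower from compound 1 to compound 4 (within the scatter). Compound 4 is therefore expected near 84%, with a range from 70% to 95%.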

Compound 4, percent of the compound remaining: 95%
Estimate against measurement, compound 4: 11 percentage points below, within the range that was stated.
By their numbers in this assay, from the lowest: compounds 2, 1, 3 and 4 (each within the scatter of the next, the first and the last beyond it).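

Cyano in place of methoxy, ortho to the (2-amino-2,4-dimethylpentyl)oxy group and two atoms from the ring nitrogen, gives the first one-place step in the series in this assay: a number 9 percentage points higher from compound 1 to compound 4 (within the scatter). At this position the two groups therefore cannot be told apart in this read-out, and the shared core tolerates either. No measurement at hand bears on the reason for this step.

Still open, as far as these compounds go, is how an amine, a carboxylic acid or a longer alkoxy chain would read at this position. Also open, from the compounds shown here alone, is whether the same exchange gives a similar step with the acetamide of compounds 2 and 3 in place of the methyl carbamate.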